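Bromo for Fluoro: A Single Halogen Swap

The compounds below may be only part of what the source reports. "The series", "measured", "known", "first", "only" and "open" are said of these compounds alone.

In a functional assay on SAOS-2 cells (Homo sapiens) for antiproliferative activity, read by MTT assay, with a stated time of 72 h (on this read-out lower numbers stand for stronger inhibition and higher numbers for weaker inhibition), compound 1 `CCCCCOC1=C(C(=O)c2ccccc2)C(c2ccc(Br)cc2)N(CCCn2ccnc2)C1=O` gives 9990 nM. Compound 2 `O=C(C1=C(Nc2ccc(F)cc2)C(=O)N(CCCn2ccnc2)C1c1ccc(Br)cc1)c1ccccc1` gives 32700 nM, the higher of the two numbers, set apart from compound 1 by a 3.3-fold higher number from compound 1 to compound 2 (0.51 log units; beyond the scatter). Compound 3 `O=C(C1=C(Nc2ccc(Br)cc2)C(=O)N(CCCn2ccnc2)C1c1ccc(Br)cc1)c1ccccc1` differs from compound 2 by bromo in place of fluoro on an aromatic carbon. Within the data shown here, no measured step bears directly on this halogen exchange; the only step measured so far replaced a different group altogether. The step from compound 2 to compound 3 is therefore expected to stay within the scatter, a 1.1-fold lower number from compound 2 to compound 3 (0.04 log units; within the scatter). Compound 3 is estimated at 30000 nM, with a range from 10000 nM to 90000 nM.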

Compound 3, half-maximal inhibitory concentration: 23800 nM
Beside the measured number, compound 3's estimate is 1.3-fold (0.10 log units) above it, and the stated range covers the measured number.
By their numbers in this assay, from the lowest: compound 1; then compounds 3 and 2 (each within the scatter of the next).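

In this assay, bromo in place of fluoro gives a 1.4-fold lower number from compound 2 to compound 3 (0.14 log units; within the scatter) so the two halogens on this aromatic carbon cannot be told apart here. The second (4-halophenyl)amino compound also stands clear of the pentyloxy compound, with a 2.4-fold higher number from compound 1 to compound 3 (0.38 log units; beyond the scatter) so both amino compounds now give higher numbers than compound 1. No outside measurement is available to explain either step. On these data alone, whether chloro or methoxy on this aromatic carbon would shift the number remains open, as does the effect of a plain phenylamino group or a shorter alkoxy chain in place of pentyloxy.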